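Swapping the nitrophenyl for a methoxyphenyl

The source may hold more compounds than are shown below. What is called first, only, known or untested is meant among the compounds shown, and "the series" means these compounds.

Measured in a functional assay on Ehrlich cells (Mus musculus) for cytotoxicity, tested at 100 ug/mL (a lower number here means a weaker effect, a higher number a stronger effect of the compound at the concentration tested), so far:
Compound 1 `COc1cc(N2C(N)=C(C#N)C(c3ccc([N+](=O)[O-])cc3)C3=C2CC(C)(C)CC3=O)cc(OC)c1OC`: 80%
Compound 2 `COc1cc(N2C(N)=C(C#N)C(c3cccc([N+](=O)[O-])c3)C3=C2CC(C)(C)CC3=O)cc(OC)c1OC`: 30%

Going by the values given here, compound 2 gives the lowest of the two numbers; its only neighbour is compound 1, and the single step, a number 50 percentage points lower from compound 1 to compound 2 (beyond the scatter), is large. Compound 3 `COc1ccccc1C1C(C#N)=C(N)N(c2cc(OC)c(OC)c(OC)c2)C2=C1C(=O)CC(C)(C)C2` differs from compound 2 by 2-methoxyphenyl in place of 3-nitrophenyl on a saturated ring carbon. Among the compounds with values here, no measured step covers this change; the one step known concerns a different group on the same saturated ring carbon, and it shows only that changes there can be large. The expected step of a number 15 percentage points higher from compound 2 to compound 3 (beyond the scatter) is therefore uncertain in direction. Compound 3 is estimated at 45%, with a range from 15% to 80%.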

Compound 3, a percentage reported as activity, at one concentration (the size of the read-out at that concentration, not a potency): 100%
Compound 3: middle estimate off by 55 percentage points, on the low side, and the stated range ends below it.
By their numbers in this assay, from the lowest: compound 2; then compound 1; then compound 3.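

Replacing 3-nitrophenyl with 2-methoxyphenyl on the saturated ring carbon gives a number 70 percentage points higher from compound 2 to compound 3 (beyond the scatter) in this assay, and replacing 4-nitrophenyl with it gives a number 20 percentage points higher from compound 1 to compound 3 (beyond the scatter). Among these three compounds, a nitro group is therefore not needed for a strong effect, and compound 3 stands above both nitrophenyl compounds. Nothing measured here explains this rise.

Compound 3 changes both the group on the phenyl ring and where that group sits, so the compounds shown do not separate the two. From the compounds shown here alone, how a plain phenyl or an aminophenyl on this carbon would compare also remains open.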